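Oxetan-3-yl in place of acetyl: compound 3 to compound 4

The compounds below may be only part of what the source reports. "The series", "measured", "known", "first", "only" and "open" are said of these compounds alone.

In a functional assay on A2780 cells (Homo sapiens) for cytotoxicity, read by sulforhodamine B assay, with a stated time of 72 h (on this read-out lower numbers stand for stronger inhibition and higher numbers for weaker inhibition), compound 1 `O=C(NCc1ccc(S(=O)(=O)c2cncc(C(F)(F)F)c2)cc1)N1Cc2ccncc2C1` gives 10 nM and compound 2 `CC(C)n1cc(S(=O)(=O)c2ccc(CNC(=O)N3Cc4ccncc4C3)cc2)cn1` gives 11 nM, with a 1.1-fold higher number from compound 1 to compound 2 (0.04 log units; within the scatter). Compound 3 `CC(=O)N1CCC(S(=O)(=O)c2ccc(CNC(=O)N3Cc4ccncc4C3)cc2)CC1` has the highest number of the three at 110 nM. The data show an 11-fold higher number from compound 1 to compound 3 (1.04 log units; beyond the scatter) and a 10-fold higher number from compound 2 to compound 3 (1.00 log units; beyond the scatter).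

Compound 4 `O=C(NCc1ccc(S(=O)(=O)C2CCN(C3COC3)CC2)cc1)N1Cc2ccncc2C1` carries oxetan-3-yl in place of acetyl on an amine nitrogen in a ring. Among the measured compounds shown here, no measured step isolates this change. All three measured steps replace the whole group on the sulfonyl sulfur, so they give only a rough guide. The gap shown by a 10-fold higher number from compound 2 to compound 3 (1.00 log units; beyond the scatter) indicates how far a change in that group can move the number in this series, and a smaller change at the ring nitrogen is expected to use only part of that gap. The expected change is a 2.2-fold lower number from compound 3 to compound 4 (0.34 log units; beyond the scatter), a modest move towards a lower number, though no change remains possible. The estimate for compound 4 is 50 nM, with an expected range of 15 nM to 170 nM.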

Compound 4, half-maximal inhibitory concentration: 7.4 nM
For compound 4 the middle estimate is 6.8-fold (0.83 log units) above the measured one; the whole stated range lies above it.
By their numbers in this assay, from the lowest: compounds 4, 1 and 2 (each within the scatter of the next); then compound 3.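

In this assay, the group on the amine nitrogen in a ring proves decisive for this sulfonyl substituent: oxetan-3-yl in place of acetyl gives a 15-fold lower number from compound 3 to compound 4 (1.17 log units; beyond the scatter), a step as large as those that first set compound 3 apart. The higher number of compound 3 therefore does not hold for 1-substituted piperidin-4-yl groups on the sulfonyl sulfur in general, and 1-(oxetan-3-yl)piperidin-4-yl stands level with the two aromatic groups, with a 1.5-fold lower number from compound 2 to compound 4 (0.17 log units; within the scatter) and a 1.4-fold lower number from compound 1 to compound 4 (0.13 log units; within the scatter). Nothing available accounts for the size of the step.

The compounds shown leave open whether the step follows the four-membered ring, its oxygen or the loss of the carbonyl. Cyclobutyl or methyl on the same nitrogen would separate these possibilities.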